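Aryl group variation on the shared core: toward compound 3

This account rests on a few compounds, and the source may have more. Where it says the series, first, only, none or still open, it means among the compounds named here.

Measured so far:
- compound 1, `COc1cc(N2C(N)=C(C#N)C(c3c(O)ccc4ccccc34)C3=C2CC(C)(C)CC3=O)cc(OC)c1OC`, in a functional assay on Ehrlich cells (Mus musculus) for cytotoxicity, tested at 50 ug/mL (a higher number here means a stronger effect of the compound at the concentration tested, a lower number a weaker effect), compound 1 gives 15%
- compound 2, `COc1cc(N2C(N)=C(C#N)C(c3ccccc3Cl)C3=C2CC(C)(C)CC3=O)cc(OC)c1OC`, in this assay compound 2 gives 20%

Compound 2 carries the highest of the two numbers, but its nearest neighbour is compound 1, and the step of a number 5 percentage points higher from compound 1 to compound 2 (within the scatter) lies within the usual scatter, so the two values cannot be ordered.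

Compound 3, `COc1cc(N2C(N)=C(C#N)C(c3ccccc3)C3=C2CC(C)(C)CC3=O)cc(OC)c1OC`, is not yet measured. It differs from compound 2 by hydrogen in place of chloro on an aromatic carbon.

Going by the values given here, the only measured step that bears on this change is the one from compound 1 to compound 2, where a much larger replacement, 2-chlorophenyl in place of 2-hydroxynaphthalen-1-yl on a saturated ring carbon, gave a number 5 percentage points higher from compound 1 to compound 2 (within the scatter). The change to compound 3 is smaller, a single chloro removed from an aromatic carbon. With the whole-group swap already within scatter, no step beyond the scatter is expected in this assay for compound 3; the expected step is a number 3 percentage points lower from compound 2 to compound 3 (within the scatter).

Compound 3 is therefore expected to give about 17% in this assay, with a range from 5% to 35%.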

Compound 3, a percentage reported as activity, at one concentration (the size of the read-out at that concentration, not a potency): 8%
Compound 3: the middle estimate sits 9 percentage points above what was measured; low and high end bracket the measured number.
By their numbers in this assay, from the lowest: compounds 3, 1 and 2 (each within the scatter of the next, the first and the last beyond it).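

In this assay, going by these compounds alone, the only step beyond the scatter among the three compounds comes from the smallest change, hydrogen in place of chloro on an aromatic carbon, ortho to a large group: a number 12 percentage points lower from compound 2 to compound 3 (beyond the scatter), a modest step. Within the data shown here, this position on the aryl group can therefore register a single-atom change, even though replacing the whole group, in a number 5 percentage points higher from compound 1 to compound 2 (within the scatter), gave no step that can be read; the same holds for phenyl in place of 2-hydroxynaphthalen-1-yl, a number 7 percentage points lower from compound 1 to compound 3 (within the scatter), which leaves those two aryl groups unordered. No measurement at hand accounts for the step from 2-chlorophenyl to phenyl.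

From the compounds shown here alone, whether the step belongs to chloro itself remains open, as does whether a fluoro, a bromo or an amine on the same aromatic carbon would give a number close to that of compound 2 or that of compound 3. Each number is also a read-out at one concentration, so whether the step between compound 2 and compound 3 would hold as a difference in potency is unresolved.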